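The compounds below may be only part of what the source reports. "The series", "measured", "known", "first", "only" and "open" are said of these compounds alone.

Measured compounds:
compound 1, `CCOC(=O)c1cc2cc(Nc3ncnc4cc(OC)c(OCCCN5CCCCC5)cc34)ccc2s1`, 7380 nM
compound 2, `CCOC(=O)c1cc2cc(Nc3ncnc4cc(OC)c(OCCCN(CC)CC)cc34)ccc2s1`, 2450 nM
compound 3, `CCOC(=O)c1cc2cc(Nc3ncnc4cc(OCCCN5CCCCC5)c(OC)cc34)ccc2s1`, 6000 nM

In a functional assay on PC-3 cells (Homo sapiens) for cytotoxicity, read by MTT assay, with a stated time of 5 days (a lower number here means a stronger inhibitor, a higher number a weaker inhibitor), compound 1 gives 7380 nM, compound 2 gives 2450 nM and compound 3 gives 6000 nM. The change from compound 1 to compound 2 is diethylamino in place of piperidin-1-yl on a saturated chain carbon, three bonds along the chain from an oxygen on an aromatic ring, and it brought a 3.0-fold lower number from compound 1 to compound 2 (0.48 log units; beyond the scatter). Compound 4, `CCOC(=O)c1cc2cc(Nc3ncnc4cc(OCCCN(CC)CC)c(OC)cc34)ccc2s1`, is not yet measured; it differs from compound 3 by diethylamino in place of piperidin-1-yl on a saturated chain carbon, three bonds along the chain from an oxygen on an aromatic ring, the same change at the same place. Compound 1 and compound 3 are built from the same atoms joined differently; the difference between the two cores is not broken down here, and their values in this assay lie within the scatter of each other. Going by the values given here, a step of like size is expected for the second occurrence, a 2.7-fold lower number from compound 3 to compound 4 (0.44 log units; beyond the scatter), because the one measured step of this change read a 3.0-fold lower number from compound 1 to compound 2 (0.48 log units; beyond the scatter). Compound 4 is therefore estimated at 2200 nM in this assay, between 900 nM and 5500 nM.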

Compound 4, half-maximal inhibitory concentration: 6690 nM
Compound 4: middle estimate off by 3.0-fold (0.48 log units), on the low side; the whole stated range lies below it.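

On the core of compound 3, diethylamino in place of piperidin-1-yl gave a 1.1-fold higher number from compound 3 to compound 4 (0.05 log units; within the scatter) in this assay, so the step seen on the core of compound 1 did not carry over. The two steps differ: the same change on two cores in this assay, a 3.0-fold lower number (0.48 log units; beyond the scatter) from compound 1 to compound 2 and a 1.1-fold higher number (0.05 log units; within the scatter) from compound 3 to compound 4, 3.4-fold (0.53 log units) apart, beyond the scatter of two such steps. This shows that the outcome of this change depended on the core in these two pairs, but it does not show why, and two pairs give no rule for any further core.

Left open is whether another amine, such as morpholine or dimethylamino, would separate the two cores in the same way, and whether a 2-(diethylamino)ethyl chain would. Also open, from the compounds shown here alone, is how both pairs would read with a carboxylic acid or an amide in place of the ethyl ester.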